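A few compounds are considered here, and "the series" means these few. Any claim that something is new, unique, unknown or untested is made for them only; others in the source may bear on it.

Measured so far:
compound 1 `COc1cc(-c2cc(/C=C/C(=O)c3ccc(N)cc3)[nH]n2)cc(OC)c1OC` — -82%
compound 2 `COc1ccc(C(=O)/C=C/c2cc(-c3cc(OC)c(OC)c(OC)c3)n[nH]2)cc1` — -32%

In a functional assay on LOX IMVI cells (Homo sapiens) for cytotoxicity, read by sulforhodamine B assay, with a stated time of 48 h, tested at 100 uM (on this read-out higher numbers stand for a weaker effect at the one concentration tested and lower numbers for a stronger effect), compound 1 gives the lowest of the two numbers; compound 2 stands nearer the inactive end, and the step of a number 50 percentage points higher from compound 1 to compound 2 (beyond the scatter) is the only measured one.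

Compound 3 `COc1ccc(-c2cc(/C=C/C(=O)c3ccc(N)cc3)[nH]n2)cc1OC` differs from compound 1 by hydrogen in place of methoxy on an aromatic carbon. Among the compounds with values here, no measured step bears on that change: the one known step concerns a different group on the other ring. The expected step of a number 12 percentage points higher from compound 1 to compound 3 (beyond the scatter) is therefore small, if any, with a wide range. Compound 3 is estimated at -70%, within -95% to -30%.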

Compound 3, a percentage reported as activity, at one concentration (the size of the read-out at that concentration, not a potency): -81%
The estimate for compound 3 lay 11 percentage points above the measured number, and the stated range covers the measured number.
By their numbers in this assay, from the lowest: compounds 1 and 3 (each within the scatter of the next); then compound 2.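

Hydrogen in place of methoxy at this position, ortho to a methoxy group and meta to a large group, gives a number 1 percentage points higher from compound 1 to compound 3 (within the scatter). With the amino group held constant, this methoxy can therefore be lost with no change beyond the scatter, whereas the change on the other ring gave a number 50 percentage points higher from compound 1 to compound 2 (beyond the scatter). No available evidence accounts for either step.

Going by these compounds, whether the same loss is as quiet in the methoxy-bearing compound 2 stays open. So does the outcome of a hydroxyl, a fluorine or a longer ether chain at this position.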